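The source may report more compounds than this note shows. Statements on the series, on what has been measured and on what is new or still open speak of the compounds shown alone.

Measured in a functional assay on PC-3 cells (Homo sapiens) for cytotoxicity, read by WST assay, with a stated time of 3 days; a lower number here means a stronger inhibitor, a higher number a weaker inhibitor:
Compound 1 `CCn1ccnc1/C=C/C(=O)/C=C/c1coc2ccccc2c1=O` gives 1800 nM.
Compound 2 `CCCCn1ccnc1/C=C/C(=O)/C=C/c1coc2ccccc2c1=O` gives 2000 nM.

These two numbers cannot be told apart: the step of a 1.1-fold higher number from compound 1 to compound 2 (0.05 log units; within the scatter) lies within the scatter, so compound 2 stands level with compound 1 rather than apart from it. Compound 3 `CCCC(C)n1ccnc1/C=C/C(=O)/C=C/c1coc2ccccc2c1=O` differs from compound 2 by methyl in place of hydrogen on a saturated chain carbon bound to an aromatic nitrogen and a saturated chain carbon. Among the measured compounds shown here, the only measured step that bears on this change is the one in which the chain on the same aromatic nitrogen was lengthened, a 1.1-fold higher number from compound 1 to compound 2 (0.05 log units; within the scatter), and it produced no movement beyond the scatter. Adding one more carbon to that chain, this time as a branch, is therefore expected to leave the number roughly where compound 2 sits, with the expected step of no change at the digits printed from compound 2 to compound 3 (within the scatter) inside the scatter. Compound 3 is accordingly estimated at 2000 nM, between 1000 nM and 4000 nM.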

Compound 3, half-maximal inhibitory concentration: 3200 nM
For compound 3 the middle estimate is 1.6-fold (0.20 log units) below the measured one; measured number inside the range.
By their numbers in this assay, from the lowest: compounds 1, 2 and 3 (each within the scatter of the next).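

Placing a methyl on the saturated chain carbon bound to the aromatic nitrogen turns butyl into 1-methylbutyl, which adds a branch at this position, and in this assay this gives a 1.6-fold higher number from compound 2 to compound 3 (0.20 log units; within the scatter), so the branch does not set the two compounds apart. Measured against the ethyl group of the shorter compound, the full change gives a 1.8-fold higher number from compound 1 to compound 3 (0.25 log units; within the scatter), which means that all three chains tried on this nitrogen stand level with one another. No measurement here offers an explanation for this result.

The compounds shown leave open whether a bulkier group on this nitrogen, such as cyclohexyl or benzyl, would move the number beyond the scatter. The same question stands for a chain ending in an amine or a carboxylic acid.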